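Methoxy addition on an inactive acetylated compound

The source may report more compounds than this note shows. Statements on the series, on what has been measured and on what is new or still open speak of the compounds shown alone.

Working notes on compound 1 `COc1ccc(-c2c[nH]c(=O)n2-c2cc(OC)c(OC)c(OC)c2)cc1OC`, compound 2 `COc1ccc(-c2cn(C(C)=O)c(=O)n2-c2cc(OC)c(OC)c(OC)c2)cc1` and compound 3 `COc1ccc(-c2cn(C(C)=O)c(=O)n2-c2cc(OC)c(OC)c(OC)c2)cc1OC`. In a functional assay on ECa-109 cells (Homo sapiens) for cytotoxicity, read by MTT assay, with a stated time of 48 h (on this read-out higher numbers stand for weaker inhibition and lower numbers for stronger inhibition), compound 1 gives > 50000 nM, which is a limit and not a number. Compound 2 gives > 50000 nM, again only a limit. Both compounds therefore stand at the limit of > 50000 nM in this assay, at which 2 of the 2 values shown sit, and neither has a measured number. Compound 3 follows from compound 2 by methoxy in place of hydrogen on an aromatic carbon, with 4-methoxyphenyl becoming 3,4-dimethoxyphenyl. Within the data shown here, no measured step shows this change, so the expected step of a number no higher from compound 2 to compound 3 (the limit leaves the size open) in this assay lies within the scatter, with no direction expected. Compound 3 is estimated at 50000 nM, with an expected range of 20000 nM to 100000 nM.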

Compound 3, half-maximal inhibitory concentration: > 50000 nM
Compound 3: no number, only a limit (the forecaster's own chance of this, stated with the estimate: 85%); the middle value lies on the limit itself.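

No new step can be read among compound 1, compound 2 and compound 3, as each value is only a limit: the limit of > 50000 nM in this assay, at which 3 of the 3 values shown sit. The compounds shown leave open whether methoxy or acetyl in place of hydrogen changes potency at all.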